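Swapping chloro for nitro on a weak inhibitor

The source may report more compounds than this note shows. Statements on the series, on what has been measured and on what is new or still open speak of the compounds shown alone.

Measured in a functional assay on L1210 cells (Mus musculus) for inhibition; a higher number here means a weaker inhibitor, a lower number a stronger inhibitor:
- Compound 1 `Cc1cccc(/C=C2\Cc3ccccc3C2=O)c1`: 50400 nM
- Compound 2 `O=C1/C(=C/c2ccc(Br)cc2)CCCc2ccccc21`: 50900 nM
- Compound 3 `O=C1CCCCC/C1=C\c1cccc(Cl)c1`: 144000 nM

Compound 3 has the highest number of the three, and its distance to each of the others lies beyond the usual scatter, so it is the weakest inhibitor in this small set. The next compound, compound 4 `O=C1CCCCC/C1=C\c1cccc([N+](=O)[O-])c1`, keeps the same frame and changes one group: nitro in place of chloro on an aromatic carbon, meta to a group of 9 heavy atoms (nitro in place of chloro on an aromatic carbon).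

Among the measured compounds shown here, no two measured compounds differ in only one place, so the data give no direct guide to this swap in this assay. Compound 3 at 144000 nM sits at the top of the measured values, so a shift towards a lower number seems the likelier direction. The expected result is a 1.4-fold lower number from compound 3 to compound 4 (0.16 log units; within the scatter), a step not expected to go beyond the scatter. For compound 4 the estimated value is 100000 nM, with an expected range from 40000 nM to 220000 nM.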

Compound 4, half-maximal inhibitory concentration: 162000 nM
Beside the measured number, compound 4's estimate is 1.6-fold (0.21 log units) below it; low and high end bracket the measured number.
By their numbers in this assay, from the lowest: compounds 1 and 2 (each within the scatter of the next); then compounds 3 and 4 (each within the scatter of the next).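

In this assay, nitro in place of chloro on this aromatic carbon gives a 1.1-fold higher number from compound 3 to compound 4 (0.05 log units; within the scatter), so the two groups cannot be told apart here. Among the compounds shown here, this is the first pair in the set that differs in one place, and it shows that the position accepts nitro, with 3 heavy atoms and 2 hydrogen-bond acceptors, and chloro, with 1 heavy atom and 0 hydrogen-bond acceptors, with results within the scatter of each other. Nothing available explains this result.

On these data alone, whether any group at this position can move the number beyond the scatter stays open, and an amine or a carboxylic acid on the same carbon would be a direct test. Also open, as far as these compounds go, is whether the same swap would read alike on the core of compound 1, which sits in the lower group of values.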